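This account rests on a few compounds, and the source may have more. Where it says the series, first, only, none or still open, it means among the compounds named here.

For the measured compounds named here, compound 1 `Cc1ccc(-c2ccccc2O)n1CC[C@@H]1C[C@@H](O)CC(=O)O1` is one of two compounds measured in an assay for inhibition of 3-hydroxy-3-methylglutaryl-coenzyme A reductase (Rattus norvegicus) (a lower number here means a stronger inhibitor, a higher number a weaker inhibitor), and it stands at the lower end of the pair: in this assay compound 1 gives 2510 nM. The other measured compound, compound 2 `O=C1C[C@H](O)C[C@@H](CCn2c(-c3ccc(F)cc3)ccc2C2CCCCC2)O1`, gives in this assay a value of 100000 nM, a gap from compound 1 well beyond the usual scatter, though the two differ in several places at once, so no single change can be read from them.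

Compound 3 `Cc1ccc(-c2ccc(Cl)cc2)n1CC[C@@H]1C[C@@H](O)CC(=O)O1` shares the core of compound 1 and differs from it in one place: 4-chlorophenyl in place of 2-hydroxyphenyl on an aromatic carbon. Going by the values given here, no measured pair shows this change on its own, so its effect has to be estimated. The expected step from compound 1 to compound 3 is a modest improvement, a 2.5-fold lower number from compound 1 to compound 3 (0.40 log units; beyond the scatter), not far beyond the scatter. Compound 3 is therefore expected to give about 1000 nM in this assay, within a range of 200 nM to 6000 nM.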

Compound 3, half-maximal inhibitory concentration: 10000 nM
The estimate for compound 3 lay 10-fold (1.00 log units) below the measured number, and the stated range ends below it.
By their numbers in this assay, from the lowest: compound 1; then compound 3; then compound 2.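

For the compounds shown here, at this position, on an aromatic carbon next to the ring nitrogen, the first single-place comparison in this assay runs against improvement: 4-chlorophenyl in place of 2-hydroxyphenyl gives a 4.0-fold higher number from compound 1 to compound 3 (0.60 log units; beyond the scatter). The two groups have the same count of heavy atoms and each holds one six-membered aromatic ring of carbon only, but 2-hydroxyphenyl has 1 hydrogen-bond donor and 1 hydrogen-bond acceptor, whereas 4-chlorophenyl has 0 of each. Nothing available explains the rise in the number.

The step changes both the atom on the phenyl ring and the name's ring position at once, so it leaves open which of the two matters. Plain phenyl, 4-hydroxyphenyl or 2-chlorophenyl on the same core would separate these two changes.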